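This account rests on a few compounds, and the source may have more. Where it says the series, first, only, none or still open, it means among the compounds named here.

Compound 1 `C1=C(c2cncc(OCc3ccccc3)c2)CC2CNCC1C2` gives 0.7 nM in an in vitro assay on SH-EP1 cells for displacement of a labelled ligand from Neuronal acetylcholine receptor; alpha4/beta2 (Homo sapiens) (on this read-out lower numbers stand for stronger inhibition and higher numbers for weaker inhibition), the lowest of the three numbers measured. Compound 2 `CN1C[C@H]2C=C(c3cccnc3)C[C@H](C2)C1` gives 2.1 nM in this assay, a gap beyond the usual scatter, and compound 3 `C1=C(c2ccncc2)CC2CNCC1C2` gives 56 nM, further away still. Compound 4 `Clc1ccc(Oc2cncc(C3=CC4CNCC(C3)C4)c2)cc1` has not been measured yet; it differs from compound 1 in a single place: 4-chlorophenyl in place of benzyl on an oxygen on an aromatic ring. Going by the values given here, no measured pair shows this same exchange, so there is nothing to calibrate it against directly. The expected step of a 2.1-fold higher number from compound 1 to compound 4 (0.33 log units; beyond the scatter) is small, with no clear direction, and close to the scatter of the method. The estimate for compound 4 in this assay is therefore 1.5 nM, with a range from 0.3 nM to 8 nM.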

Compound 4, inhibition constant: 1.9 nM
The estimate for compound 4 lay 1.3-fold (0.10 log units) below the measured number; the range from low to high includes it.
By their numbers in this assay, from the lowest: compound 1; then compounds 4 and 2 (each within the scatter of the next); then compound 3.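

Exchanging benzyl for 4-chlorophenyl on the oxygen keeps the count of 7 heavy atoms, yet gives a 2.7-fold higher number from compound 1 to compound 4 (0.43 log units; beyond the scatter) in this assay as a modest step. This place therefore accepts the new group at only a small cost. No measurement at hand explains the step.

The exchange alters two things at once, adding the chlorine and removing the carbon link to the oxygen, and plain phenyl on the same oxygen would separate them. On these data alone, whether an amine or a carboxylic acid on that outer ring is accepted also stays open.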